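The source may report more compounds than this note shows. Statements on the series, on what has been measured and on what is new or still open speak of the compounds shown alone.

Compound 1, `CCOC(=O)C1=C(Nc2ccccc2)S/C(=C\c2ccc(Br)c(O)c2)C1=O`: 39.8% in a functional assay on JAR cells (Homo sapiens) for inhibition, read by MTT assay, with a stated time of 72 h, tested at 10 uM; on this read-out higher numbers stand for more inhibition at the one concentration tested (going by the name of the read-out) and lower numbers for less inhibition
Compound 2, `CCOC(=O)C1=C(Nc2ccccc2)S/C(=C\c2ccccc2O)C1=O`: 89.4% in this assay
Compound 3, `CCOC(=O)C1=C(Nc2ccc(OC)cc2)S/C(=C\c2ccc[nH]2)C1=O`: 27.6% in this assay

Of the compounds shown here, three with a shared core have been measured so far. In this assay compound 3 gives the lowest number of the three; its nearest neighbour is compound 1 with 39.8%, and the furthest is compound 2 with 89.4%, both of them beyond the scatter of compound 3.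

Going by the values given here, the one step measured between neighbours, a number 49.6 percentage points higher from compound 1 to compound 2 (beyond the scatter), concerns the group on the double-bonded chain carbon. The step from compound 3 to compound 4, `CCOC(=O)C1=C(Nc2cccc([N+](=O)[O-])c2)S/C(=C\c2ccc[nH]2)C1=O`, changes a different place: 3-nitrophenyl in place of 4-methoxyphenyl on an amine nitrogen. Among the compounds with values here, no measured pair alters the group on the amine nitrogen, so the size and direction of this step cannot be read from the data; the only measured step, large as it was, speaks to another position and gives no guide here. The expectation therefore is that compound 4 stays near compound 3, with a number 4.4 percentage points higher from compound 3 to compound 4 (within the scatter) as the step the estimate implies, which is not beyond the scatter. Compound 4 is estimated to give 32% in this assay, with a range from 10% to 55%.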

Compound 4, a percentage reported as inhibition, at one concentration (the size of the read-out at that concentration, not a potency): 57.4%
The estimate for compound 4 lay 25.4 percentage points below the measured number; measured number outside the range, above it.
By their numbers in this assay, from the lowest: compound 3; then compound 1; then compound 4; then compound 2.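

With the group on the double-bonded chain carbon held fixed, replacing 4-methoxyphenyl with 3-nitrophenyl on the amine nitrogen gave, in this assay, a number 29.8 percentage points higher from compound 3 to compound 4 (beyond the scatter). Going by these compounds alone, the group on the amine nitrogen can therefore change this read-out on its own, so the earlier step at the chain carbon, a number 49.6 percentage points higher from compound 1 to compound 2 (beyond the scatter), is no longer the only measured change beyond the scatter. The result comes with no measurement that bears on the reason for this step.

The compounds shown leave open whether the step follows from the nitro group itself or from the change in its place on the ring, since 4-methoxyphenyl and 3-nitrophenyl differ in both, and a 4-nitrophenyl or 3-methoxyphenyl group on the amine nitrogen would separate the two. Within the data shown here, they also leave open whether the same change would act alike with 2-hydroxyphenyl or 4-bromo-3-hydroxyphenyl on the chain carbon, because compound 1 and compound 2 carry an unsubstituted phenyl on the amine nitrogen and no pair links them to compound 3 or compound 4 through one change.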